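Swapping methyl for isopropyl on compound 3

The source may report more compounds than this note shows. Statements on the series, on what has been measured and on what is new or still open speak of the compounds shown alone.

Of the compounds shown here, three sharing one core have been measured so far in an ADME assay on microsomes (Mus musculus) for metabolic stability; on this read-out lower numbers stand for slow clearance and higher numbers for fast clearance. Compound 1 `CNC(=O)[C@@H]1CCCN1S(=O)(=O)c1ccc(Cl)c(COc2cccc3c(-n4ccnc4)cc(C)nc23)c1Cl` carries 1H-imidazol-1-yl and gives 267 mL/min/kg as its clearance. Compound 2 `CNC(=O)[C@@H]1CCCN1S(=O)(=O)c1ccc(Cl)c(COc2cccc3c(-c4ccccn4)cc(C)nc23)c1Cl` carries pyridin-2-yl and gives 733 mL/min/kg on the same scale. Compound 3 `CNC(=O)[C@@H]1CCCN1S(=O)(=O)c1ccc(Cl)c(COc2cccc3c(-c4ccncc4)cc(C)nc23)c1Cl` carries pyridin-4-yl and gives 550 mL/min/kg on the same scale. Compound 3 therefore stands level with its pyridin-2-yl partner, as the step of a 1.3-fold lower number from compound 2 to compound 3 (0.12 log units; within the scatter) shows, and clearly above the imidazole compound, with a 2.1-fold higher number from compound 1 to compound 3 (0.31 log units; beyond the scatter) as the gap.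

Compound 4 `CNC(=O)[C@@H]1CCCN1S(=O)(=O)c1ccc(Cl)c(COc2cccc3c(-c4ccncc4)cc(C(C)C)nc23)c1Cl` keeps all of compound 3 except for one change: isopropyl in place of methyl on an aromatic carbon, next to the ring nitrogen (isopropyl in place of methyl on an aromatic carbon). For the measured compounds named here, no measured step alters this group, so the evidence is only indirect. The largest single swap seen so far, a 2.7-fold higher number from compound 1 to compound 2 (0.44 log units; beyond the scatter), was modest and involved a different group. The direction of any effect cannot be read from these data, and no step beyond the scatter is expected. The estimated change is a 1.1-fold higher number from compound 3 to compound 4 (0.05 log units; within the scatter) as a cautious guess. Compound 4 is expected to read 620 mL/min/kg in this assay, with an estimated range from 330 mL/min/kg to 1100 mL/min/kg for the measurement.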

Compound 4, clearance: 633 mL/min/kg
Compound 4: middle estimate off by 1.0-fold (0.01 log units), on the low side, and the stated range covers the measured number.
By their numbers in this assay, from the lowest: compound 1; then compounds 3, 4 and 2 (each within the scatter of the next).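

For the compounds shown here, this is the first measured swap at this position, the aromatic carbon next to the ring nitrogen of the shared core, and in this assay isopropyl in place of methyl gives a 1.2-fold higher number from compound 3 to compound 4 (0.06 log units; within the scatter). Compound 3 and compound 4 therefore read level on this clearance scale, even though the group at this place grows from 1 carbon to 3 carbons, so on this evidence the position accepts a branched group of this size without a shift beyond the usual scatter of the measurement. The data offer no measurement that could explain why the two compounds read level.

Going by these compounds alone, the swap has been read only with the pyridin-4-yl group in the molecule, so it remains open whether isopropyl would read the same way alongside the 1H-imidazol-1-yl or pyridin-2-yl groups of the earlier compounds. Also open, from the compounds shown here alone, is whether this position would stay as undemanding with a different kind of group there, such as an amine, a carboxylic acid or a chain longer than isopropyl.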